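The source may report more compounds than this note shows. Statements on the series, on what has been measured and on what is new or still open speak of the compounds shown alone.

Measured compounds:
compound 1 `CCC(CC)(c1nnc[nH]1)c1ccc(-c2ccc3cc(F)cc(F)c3c2)[nH]c1=O` — 89 nM
compound 2 `CC(C)C(Cc1nnc[nH]1)c1ccc(-c2ccc3cccc(F)c3c2)[nH]c1=O` — 10 nM

Notes on the series. Within the data shown here, in an assay on CHO cells for displacement of a labelled ligand from prostaglandin E2 receptor EP3 subtype (Homo sapiens), read by radioligand binding (on this read-out lower numbers stand for stronger inhibition and higher numbers for weaker inhibition), compound 2 gives 10 nM, the lower of the two numbers known so far; compound 1 gives 89 nM, a weaker result, and the gap between the two lies beyond the scatter. Compound 1 and compound 2 differ in more than one place, so nothing is attributed to any single change between them.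

Compound 3 `CC(C)C(Cc1noc(=O)[nH]1)c1ccc(-c2ccc3cccc(F)c3c2)[nH]c1=O` is not yet measured. It differs from compound 2 in one place: a group of 6 heavy atoms (2 carbon, 2 nitrogen, 2 oxygen; one five-membered aromatic ring with 3 hetero atoms) in place of a group of 5 heavy atoms (2 carbon, 3 nitrogen; one five-membered aromatic ring with 3 hetero atoms), on a saturated chain carbon, two bonds along the chain from an aromatic carbon. Among the measured compounds shown here, no step between measured compounds bears on this change, so the expectation rests on the value of compound 2 alone. A step in this assay from compound 2 to compound 3 of about a 1.5-fold higher number from compound 2 to compound 3 (0.18 log units; within the scatter) is expected, toward a somewhat weaker result, though a step within the scatter is just as plausible. Compound 3 is thus estimated at 15 nM in this assay, with a range from 5 nM to 50 nM.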

Compound 3, inhibition constant: 34 nM
Estimate against measurement, compound 3: 2.3-fold (0.36 log units) below; measured number inside the range.
By their numbers in this assay, from the lowest: compound 2; then compound 3; then compound 1.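

At the saturated chain carbon, two bonds along the chain from an aromatic carbon, the choice of ring matters: in this assay, replacing 4H-1,2,4-triazol-3-yl with the ring of compound 3 gives a 3.4-fold higher number from compound 2 to compound 3 (0.53 log units; beyond the scatter), a modest step. Both are five-membered aromatic rings with 3 hetero atoms and neither carries a net charge, so these shared features do not by themselves fix the value at this place. Nothing available explains the step or assigns it to a particular feature of either ring.

As far as these compounds go, whether a carboxylic acid or a tetrazole at this place would stay closer to compound 2 or fall further away remains open. Also open, from the compounds shown here alone, is whether the same ring exchange gives a step of similar size on the core of compound 1.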